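This account rests on a few compounds, and the source may have more. Where it says the series, first, only, none or still open, it means among the compounds named here.

Series notes. In an assay on CHO cells for displacement of a labelled ligand from adenosine receptor A1 (Homo sapiens), read by scintillation counting, tested at 10 uM (on this read-out higher numbers stand for more inhibition at the one concentration tested (going by the name of the read-out) and lower numbers for less inhibition), compound 1 `CC(C)(C)Cc1c(-c2ccoc2)sc(N)c1C(=O)c1ccc(Cl)cc1` gives 1%; compound 2 `CC(C)(C)Cc1c(-c2ccccc2)sc(N)c1C(=O)c1cccc(Cl)c1` gives 2%, and compound 3 `CC(C)(C)Cc1c(-c2ccccc2)sc(N)c1C(=O)c1cccc(C(F)(F)F)c1` gives 1%. Compound 1 stands level with compound 3 at the digits shown, and compound 2 sits only marginally apart, all three within the usual scatter of one another. Among the compounds with values here, the single measured step, a number 1 percentage points lower from compound 2 to compound 3 (within the scatter), concerns a substituent on the benzoyl side of the shared core and lies within the scatter. Compound 4 `Cc1noc(C)c1-c1sc(N)c(C(=O)c2ccc(Cl)cc2)c1CC(C)(C)C` differs from compound 1 by 3,5-dimethyl-1,2-oxazol-4-yl in place of furan-3-yl on an aromatic carbon. Within the data shown here, no measured step touches this ring, and all three numbers sit at the floor of the read-out. Compound 4 is therefore expected to remain near that floor, with an expected step of a number 1 percentage points higher from compound 1 to compound 4 (within the scatter) and an estimate of 2% in a range from -6% to 10%.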

Compound 4, a percentage reported as inhibition, at one concentration (the size of the read-out at that concentration, not a potency): 1%
Compound 4: middle estimate off by 1 percentage points, on the high side, within the range that was stated.
By their numbers in this assay, from the lowest: compounds 1, 3, 4 and 2 (each within the scatter of the next).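

In this assay the position next to the ring sulfur takes 3,5-dimethyl-1,2-oxazol-4-yl in place of furan-3-yl, with no change at the digits printed from compound 1 to compound 4 (within the scatter). This exchange of one five-membered aromatic ring for another, bringing in a ring nitrogen and methyl groups, leaves the number at the floor of the read-out. No measurement available here explains this result.

Going by these compounds, whether an amine, a carboxylic acid or a longer chain at this position would move the number remains open. Also open, on these data alone, is whether any change to the shared core gives inhibition beyond the scatter.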